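This account rests on a few compounds, and the source may have more. Where it says the series, first, only, none or still open, it means among the compounds named here.

In a functional assay on A549 cells (Homo sapiens) for cytotoxicity, read by sulforhodamine B assay (a higher number here means a weaker inhibitor of growth, a lower number a stronger inhibitor of growth), compound 3 `COc1ccc2c(c1)C(=O)CCN2c1nc(Cl)nc2ccccc12` gives 27 nM and compound 1 `Cc1ccc2c(c1)CCCN2c1nc(Cl)nc2ccccc12` gives 43 nM, two values within the scatter of each other. Compound 2 `Cc1ccc2c(c1)CCCN2c1nc(C)nc2ccccc12`, at 211 nM, has the highest number of the three, beyond the scatter from both. Compound 4 `COc1ccc2c(c1)C(=O)CCN2c1nc(C)nc2ccccc12` differs from compound 3 by a single change: methyl in place of chloro on an aromatic carbon. This is methyl in place of chloro on an aromatic carbon, between two ring nitrogen atoms. Among the compounds with values here, one measured step bears on it, the same exchange on the core of compound 1: a 4.9-fold higher number from compound 1 to compound 2 (0.69 log units; beyond the scatter), a modest step beyond the scatter. Compound 3 and compound 1 differ elsewhere on their cores, and the data do not show whether the step carries over in full. A step of similar size toward a higher number is therefore expected in this assay, with a wide margin. The estimated step is a 4.8-fold higher number from compound 3 to compound 4 (0.68 log units; beyond the scatter). For compound 4 the expected value is 130 nM, with an estimated range of 50 nM to 330 nM.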

Compound 4, concentration for 50% growth inhibition: 24 nM
Beside the measured number, compound 4's estimate is 5.4-fold (0.73 log units) above it, and the stated range ends above it.
By their numbers in this assay, from the lowest: compounds 4, 3 and 1 (each within the scatter of the next); then compound 2.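

Methyl in place of chloro, on an aromatic carbon between two ring nitrogen atoms, has no single effect in this assay: on this second core the exchange gives a 1.1-fold lower number from compound 3 to compound 4 (0.05 log units; within the scatter), and the clear rise seen on the core of compound 1 does not recur. Chloro at this position is therefore not needed for a low number on every core. The outcome of the exchange differs with the core that carries it: the same change on two cores in this assay, a 4.9-fold higher number (0.69 log units; beyond the scatter) from compound 1 to compound 2 and a 1.1-fold lower number (0.05 log units; within the scatter) from compound 3 to compound 4, 5.5-fold (0.74 log units) apart, beyond the scatter of two such steps

As far as these compounds go, compound 3 and compound 1 differ in more than one place on their cores, so it remains open whether the carbonyl, the methoxy or both together account for this difference. From the compounds shown here alone, how an amine or an ethyl chain at this position would stand in this assay also remains open.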